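Swapping the urea aryl group on an inactive sulfonamide

The source may report more compounds than this note shows. Statements on the series, on what has been measured and on what is new or still open speak of the compounds shown alone.

Compound 1 `Cc1ccc(-c2ccsc2S(=O)(=O)NCCNC(=O)Nc2cccc([N+](=O)[O-])c2)c(Oc2ccc(O)c(O)c2)c1` gives > 20000 nM in a functional assay on HeLa cells (Homo sapiens) for inhibition, read by CCK-8 assay, with a stated time of 48 h; a lower number here means a stronger inhibitor, a higher number a weaker inhibitor.
Compound 2 `COc1ccc(NC(=O)NCCNS(=O)(=O)c2ccc(-c3ccccc3OCc3cccc(O)c3)s2)cc1` gives > 20000 nM in this assay.

Compound 1 stands at a limit of the assay, not at a number. Compound 2 also reports only a limit. Both measured compounds therefore share (the limit of > 20000 nM in this assay, at which 2 of the 2 values shown sit).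

Compound 3 `COc1ccc(NC(=O)NCCNS(=O)(=O)c2sccc2-c2ccc(C)cc2Oc2ccc(O)c(O)c2)cc1` differs from compound 1 by 4-methoxyphenyl in place of 3-nitrophenyl on an amide-type nitrogen. For the measured compounds named here, no step between measured compounds is known, so the expected step that the limit leaves unreadable from compound 1 to compound 3 is none beyond the scatter, because the limit of > 20000 nM in this assay, at which 2 of the 2 values shown sit, holds for both measured compounds. Compound 3 is therefore expected to give 30000 nM, within 10000 nM to 100000 nM, most likely again as a limit.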

Compound 3, half-maximal inhibitory concentration: > 20000 nM
Compound 3 ended at the assay's limit; the forecaster's own chance of this, stated with the estimate: 85%; the middle value lies beyond the limit too.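

Compound 1 and compound 3 both stop at a limit of this assay, not at a number, so no step between them can be read: the limit of > 20000 nM in this assay, at which 3 of the 3 values shown sit.

The compounds shown leave open whether 4-methoxyphenyl in place of 3-nitrophenyl changes inhibition at all.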